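Moving the ring nitrogen: from compound 3 to compound 4

The compounds below may be only part of what the source reports. "The series", "measured", "known", "first", "only" and "open" are said of these compounds alone.

Measured so far in an assay on FRT cells with Cystic fibrosis transmembrane conductance regulator variant F508del (Homo sapiens) as the target, read by fluorescence, with a stated time of 25 min; a higher number here means a larger maximal response, a lower number a smaller maximal response:
compound 1 `CN1CCN(CCCNc2nc(-c3ccccn3)nc3c2CN(Cc2ccccc2)CC3)CC1`: 53.4%
compound 2 `NC(=O)C1CCN(c2nc(-c3cccnc3)nc3c2CN(Cc2ccccc2)CC3)CC1`: "not active" (no number reported)
compound 3 `CN1CCN(CCCNc2nc(-c3cccnc3)nc3c2CN(Cc2ccccc2)CC3)CC1`: "not active" (no number reported)

Compound 3 stands without a number: in this assay compound 3 was reported as "not active" (no number reported), and compound 2, which shares the pyridin-3-yl group with it, was likewise reported as "not active" (no number reported). For the measured compounds named here, compound 1 differs from compound 3 in how the atoms of its six-membered aromatic ring with one hetero atom are joined, and it is the only one that gives a number: in this assay compound 1 gives 53.4%.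

Compound 4 `CN1CCN(CCCNc2nc(-c3ccncc3)nc3c2CN(Cc2ccccc2)CC3)CC1` differs from compound 3 in a single place: pyridin-4-yl in place of pyridin-3-yl on an aromatic carbon. The two compounds hold the same atoms, joined differently.

Going by the values given here, no measured pair here tells the size of such a change, and compound 3 itself has no number from which a step could be counted. Among the compounds with values here, the two compounds carrying pyridin-3-yl gave no value; the one compound with a different joining gave a moderate one. As far as these compounds go, whether pyridin-4-yl behaves like either is unknown, so the expected step could be none or a rise to a measurable response.

Compound 4 is therefore expected to give about 20% in this assay, within a range from 0% to 55%.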

Compound 4, largest response reached (Emax), in percent of the reference or control that the assay uses: "not active" (no number reported)
For compound 4 the study gives words and no number; no gap can be computed for the estimate.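

In this assay compound 3 and compound 4 were both reported as not active, without a number, so no step can be read between them. The compounds shown leave open whether pyridin-4-yl and pyridin-3-yl differ at all in this read-out. Nothing measured here offers an explanation for the result.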